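Dropping the fluoro from a benzylamide agonist

A few compounds are considered here, and "the series" means these few. Any claim that something is new, unique, unknown or untested is made for them only; others in the source may bear on it.

Compound 3 `Cc1nn(-c2ncnc3nc[nH]c23)c2c1C(C(=O)NCc1ccc(F)cc1)CC(=O)N2` gives 4 nM in a functional assay on HEK293 cells for agonist activity at G-protein coupled receptor 39 (Homo sapiens), read by scintillation proximity assay and inositol phosphate accumulation, with a stated time of 75 min, in the presence of a further agent that is not named here (on this read-out higher numbers stand for an effect only at larger amounts of compound and lower numbers for an effect already at smaller amounts), the second highest of the three numbers: compound 1 `Cc1nn(-c2ncnc3nc[nH]c23)c2c1C(OC1CCCC1)CC(=O)N2` gives 2 nM, within the scatter of compound 3, while compound 2 `Cc1nn(-c2ncnc3nc[nH]c23)c2c1C(C(=O)N(C)c1nccs1)CC(=O)N2` gives 18 nM, beyond it. Compound 4 `Cc1nn(-c2ncnc3nc[nH]c23)c2c1C(C(=O)NCc1ccccc1)CC(=O)N2` differs from compound 3 by hydrogen in place of fluoro on an aromatic carbon; the change sits on a six-membered aromatic ring of carbon only, para to a large group, and takes the 4-fluorobenzyl to benzyl. The measured steps, a 9.0-fold higher number from compound 1 to compound 2 (0.95 log units; beyond the scatter) and a 4.5-fold lower number from compound 2 to compound 3 (0.65 log units; beyond the scatter), each alter a different part of the molecule and neither removes a fluoro, so they do not bear directly on this change. Compound 4 is therefore expected to show no step beyond the scatter, no change at the digits printed from compound 3 to compound 4 (within the scatter). Compound 4 is estimated at 4 nM, in a range from 1.5 nM to 11 nM.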

Compound 4, half-maximal effective concentration: 5 nM
The estimate for compound 4 lay 1.3-fold (0.10 log units) below the measured number; measured number inside the range.
By their numbers in this assay, from the lowest: compounds 1, 3 and 4 (each within the scatter of the next, the first and the last beyond it); then compound 2.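

Taking the fluoro off the aromatic carbon gives a 1.3-fold higher number from compound 3 to compound 4 (0.10 log units; within the scatter) and so, at this position, the 4-fluorobenzyl and benzyl amides cannot be told apart. The benzylamino group keeps the gain over methyl(1,3-thiazol-2-yl)amino on the carbonyl carbon, with a 3.6-fold lower number from compound 2 to compound 4 (0.56 log units; beyond the scatter) as the printed step, while benzylcarbamoyl in place of cyclopentyloxy gives a 2.5-fold higher number from compound 1 to compound 4 (0.40 log units; beyond the scatter) as a gap that compound 3, within the scatter of compound 1, did not open. No evidence on hand accounts for these steps.

Going by these compounds, whether a chloro, methoxy or amine on that aromatic carbon would leave the number unchanged remains open. So does the effect of a fluoro elsewhere on the ring.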